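The source may hold more compounds than are shown below. What is called first, only, known or untested is meant among the compounds shown, and "the series" means these compounds.

Compound 1, `C=C(C)[C@@H]1CC=C(Cn2cc(COc3cc(C4NC(=O)NC(C)=C4C(=O)OCC)ccc3OC)nn2)CC1`: in a functional assay on NCI/ADR-RES cells (Homo sapiens) for inhibition, read by sulforhodamine B assay, with a stated time of 48 h (a lower number here means a stronger inhibitor of growth, a higher number a weaker inhibitor of growth), compound 1 gives > 100000 nM, which is a limit of the assay and not a number.
Compound 2, `C=C(C)[C@@H]1CC=C(Cn2cc(COc3cccc(C4NC(=O)NC(C)=C4C(C)=O)c3)nn2)CC1`: in this assay compound 2 gives > 100000 nM, again only a limit.
Compound 3, `C=C(C)[C@@H]1CC=C(Cn2cc(COc3cccc(C4NC(=O)NC5=C4C(=O)CC(C)(C)C5)c3)nn2)CC1`: in this assay compound 3 gives > 100000 nM, also a limit.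

Within the data shown here, compound 3 therefore stands at the limit of > 100000 nM in this assay, at which 3 of the 3 values shown sit; no number is known for it, and since no two measured compounds differ in a single place, no step size has been seen anywhere. Compound 4, `C=C(C)[C@@H]1CC=C(Cn2cc(COc3cc(C4NC(=O)NC5=C4C(=O)CC(C)(C)C5)ccc3OC)nn2)CC1`, differs from compound 3 by methoxy in place of hydrogen on an aromatic carbon. Every measured compound, compound 1 and compound 2 included, sits at the same limit, so the series gives no sign that a change of this kind moves the read-out. The step from compound 3 to compound 4 is accordingly expected to be a step that the limit leaves unreadable from compound 3 to compound 4, none beyond the scatter. The estimate for compound 4 in this assay is 150000 nM, with a range of 50000 nM to 500000 nM, and most likely the assay will again report only a limit.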

Compound 4, concentration for total growth inhibition: > 100000 nM
Compound 4 ended at the assay's limit; the forecaster's own chance of this, stated with the estimate: 85%; the middle value does not contradict the limit.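

No step can be read from compound 3 to compound 4, because both stand at the same limit in this assay: the limit of > 100000 nM in this assay, at which 4 of the 4 values shown sit.

The compounds shown leave open how strongly any of them inhibits growth, and whether methoxy in place of hydrogen on an aromatic carbon changes that at all.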